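From Nitrophenyl to Naphthalenyl on the Sulfonamide Nitrogen

This account rests on a few compounds, and the source may have more. Where it says the series, first, only, none or still open, it means among the compounds named here.

Measured compounds:
compound 1, `O=C1C(Cl)=C(Nc2ccc(S(=O)(=O)Nc3ccccc3[N+](=O)[O-])cc2)C(=O)c2ccccc21`: 3990 nM
compound 2, `O=C1C(Cl)=C(Nc2ccc(S(=O)(=O)Nc3ccc([N+](=O)[O-])cc3)cc2)C(=O)c2ccccc21`: 2840 nM

In a functional assay on MCF7 cells (Homo sapiens) for antiproliferative activity, read by MTT assay, with a stated time of 48 h (a higher number here means a weaker inhibitor, a lower number a stronger inhibitor), compound 1 gives 3990 nM and compound 2 gives 2840 nM. Going by the values given here, the step of a 1.4-fold lower number from compound 1 to compound 2 (0.15 log units; within the scatter) is the only measured comparison, and it leaves compound 2 with the lowest of the two numbers, though its distance to compound 1 lies within the scatter, so neither compound can be called the stronger inhibitor. Compound 3, `O=C1C(Cl)=C(Nc2ccc(S(=O)(=O)Nc3cccc4ccccc34)cc2)C(=O)c2ccccc21`, carries a different change: naphthalen-1-yl in place of 4-nitrophenyl on a sulfonamide nitrogen. Among the compounds with values here, no measured step removes the nitro group or brings in naphthalen-1-yl; the single step on record only exchanged 2-nitrophenyl for 4-nitrophenyl and stayed within the scatter, so it gives little guidance here. Lacking a comparable precedent, compound 3 is expected to sit close to its predecessor, the step of a 1.1-fold lower number from compound 2 to compound 3 (0.06 log units; within the scatter) being estimated as small and uncertain in direction. Compound 3 is therefore estimated at 2500 nM, within a range of 800 nM to 8000 nM.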

Compound 3, half-maximal inhibitory concentration: 3320 nM
Compound 3: the middle estimate sits 1.3-fold (0.12 log units) below what was measured, and the stated range covers the measured number.
By their numbers in this assay, from the lowest: compounds 2, 3 and 1 (each within the scatter of the next).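

In this assay, naphthalen-1-yl on the sulfonamide nitrogen gives a 1.2-fold higher number from compound 2 to compound 3 (0.07 log units; within the scatter), and set against the other nitrophenyl compound it gives a 1.2-fold lower number from compound 1 to compound 3 (0.08 log units; within the scatter). The earlier pair only moved a nitro group within a nitrophenyl substituent, whereas this change removes the nitro group altogether and brings in a group of carbon only, with no hydrogen-bond acceptors, and all three numbers still lie within the scatter of one another. Nothing measured here accounts for this lack of separation.

The compounds shown leave open whether a carboxylic acid, an amine or a short alkyl chain in place of naphthalen-1-yl on the sulfonamide nitrogen would also stay within this range. All three share one core, so they also leave open how changes elsewhere on it would read.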